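Phenyl for methylpyridinyl on the piperidine of compound 3

The source may report more compounds than this note shows. Statements on the series, on what has been measured and on what is new or still open speak of the compounds shown alone.

In a functional assay on cells for agonist activity at D(4) dopamine receptor (Homo sapiens), read by TR-FRET and cAMP accumulation, with a stated time of 30 min (a lower number here means that less compound is needed, a higher number that more compound is needed for the effect), the measured compounds stand as follows:
compound 1 `Cc1cccc(NC(=O)CN2CCN(c3cccc4ccccc34)CC2)c1` gives 109 nM
compound 2 `Cc1cccc(NC(=O)CN2CCN(c3ccc(Cl)cn3)CC2)c1` gives "not active" (no number reported)
compound 3 `Cc1ccc(C2CCN(CC(=O)Nc3cccc(C)c3)CC2)nc1` gives "not active" (no number reported)

Compound 3 therefore carries no single number in this assay, and compound 2 is a further entry without one; only compound 1 has a measured value. The next compound, compound 4 `Cc1cccc(NC(=O)CN2CCC(c3ccccc3)CC2)c1`, differs from compound 3 by one change: phenyl in place of 5-methylpyridin-2-yl on a saturated ring carbon. For the measured compounds named here, no measured pair shows this change, so its size and direction in this assay cannot be read from the data. With compound 3 lacking a number, the expectation can only be that compound 4 either gains a measurable value or again returns none. Compound 4 is estimated at 2000 nM in this assay, with a range from 200 nM to 20000 nM.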

Compound 4, half-maximal effective concentration: 15.4 nM
Compound 4: the middle estimate sits 130-fold (2.11 log units) above what was measured; measured number outside the range, below it.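

No step can be read from compound 3 to compound 4, since compound 3 carries no number. The compounds shown leave open how far phenyl in place of 5-methylpyridin-2-yl shifts the value, and no measurement here offers an explanation for the result.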